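A few compounds are considered here, and "the series" means these few. Any claim that something is new, unique, unknown or untested is made for them only; others in the source may bear on it.

Measured so far:
compound 1, `COc1cc(-c2cc(/C=C/C(=O)c3ccc(Cl)c(Cl)c3)[nH]n2)cc(OC)c1OC`, in a functional assay on RXF 393 cells (Homo sapiens) for cytotoxicity, read by sulforhodamine B assay, with a stated time of 48 h, tested at 100 uM (on this read-out higher numbers stand for a weaker effect at the one concentration tested and lower numbers for a stronger effect), gives -71%
compound 2, `COc1ccc(C(=O)/C=C/c2cc(-c3cc(OC)c(OC)c(OC)c3)n[nH]2)cc1OC`, in this assay gives -98%

On these two numbers compound 2 stands lowest, that is with the stronger effect, because a number 27 percentage points lower from compound 1 to compound 2 (beyond the scatter). Compound 3, `COc1ccc(C(=O)/C=C/c2cc(-c3cc(OC)c(OC)c(OC)c3)n[nH]2)cc1`, differs from compound 2 in one place: hydrogen in place of methoxy on an aromatic carbon. Going by the values given here, only one measured step is available, and it bears on the same ring: a number 27 percentage points lower from compound 1 to compound 2 (beyond the scatter) exchanged one whole aryl group for another and moved the number by a modest amount. Among the compounds with values here, no measured step removes a single methoxy group from that ring, so there is no direct guide. A change this small is expected to leave the number within the scatter of this assay, or to raise it only slightly toward a weaker effect. Compound 3 is therefore expected to give about -88%, between -105% and -62%, an expected step of a number 10 percentage points higher from compound 2 to compound 3 (within the scatter).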

Compound 3, a percentage reported as activity, at one concentration (the size of the read-out at that concentration, not a potency): -93%
Compound 3: middle estimate off by 5 percentage points, on the high side; low and high end bracket the measured number.
By their numbers in this assay, from the lowest: compounds 2 and 3 (each within the scatter of the next); then compound 1.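

In this assay, the change from 3,4-dimethoxyphenyl to 4-methoxyphenyl gives a number 5 percentage points higher from compound 2 to compound 3 (within the scatter) and so shows that this methoxy group, ortho to the other methoxy group on the ring, can be replaced by hydrogen without a step that stands out from the usual scatter. The 4-methoxyphenyl group in place of 3,4-dichlorophenyl gives a number 22 percentage points lower from compound 1 to compound 3 (beyond the scatter) and so shows that the gap to the dichloro compound does not depend on having both methoxy groups on this ring. Nothing measured here explains either step.

Still open, from the compounds shown here alone, is whether the effect would hold if the last methoxy group on this ring were also replaced by hydrogen. Going by these compounds, it is equally open how a hydroxyl group, an amine or a carboxylic acid would read out at the position studied here.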